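This account rests on a few compounds, and the source may have more. Where it says the series, first, only, none or still open, it means among the compounds named here.

In a functional assay (Nicotiana tabacum) (a lower number here means a stronger inhibitor, a higher number a weaker inhibitor), three compounds with a shared core have been measured: compound 1 `CNc1nc(SC)nc2ncccc12` gives 2920 nM, compound 2 `CCC(CC)Nc1nc(SC)nc2ncccc12` gives 2720 nM, and compound 3 `COCCNc1nc(SC)nc2ncccc12` gives 2530 nM. Compound 3 therefore stands level with the other two, within the scatter of both. The next compound, compound 4 `CSc1nc(Nc2ccccc2)c2cccnc2n1`, carries phenyl in place of 2-methoxyethyl on a nitrogen on an aromatic ring. Among the compounds with values here, three measured steps bear on this change, since each swaps the group at this same place. They are a 1.1-fold lower number from compound 1 to compound 2 (0.03 log units; within the scatter), a 1.2-fold lower number from compound 1 to compound 3 (0.06 log units; within the scatter) and a 1.1-fold lower number from compound 2 to compound 3 (0.03 log units; within the scatter). Methyl, pentan-3-yl and 2-methoxyethyl thus give numbers that cannot be told apart. On these data alone, none of these groups contains a ring, however, so phenyl remains untested and the range must stay wide. The data favour no direction, so no change beyond the scatter is expected. The expected result is a 1.0-fold lower number from compound 3 to compound 4 (0.01 log units; within the scatter). For compound 4 the estimated value is 2500 nM, with an expected range from 900 nM to 7000 nM.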

Compound 4, half-maximal inhibitory concentration: 15900 nM
Compound 4: middle estimate off by 6.4-fold (0.80 log units), on the low side; measured number above the stated range.
By their numbers in this assay, from the lowest: compounds 3, 2 and 1 (each within the scatter of the next); then compound 4.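

In this assay, the group on a nitrogen on an aromatic ring does matter: phenyl gives a 6.3-fold higher number from compound 3 to compound 4 (0.80 log units; beyond the scatter), a 5.8-fold higher number from compound 2 to compound 4 (0.77 log units; beyond the scatter) and a 5.4-fold higher number from compound 1 to compound 4 (0.74 log units; beyond the scatter). Methyl, pentan-3-yl and 2-methoxyethyl could not be told apart, so phenyl, the only one of these groups with a ring, is the first to shift the number beyond the scatter, and the shift is towards a weaker inhibitor. Nothing measured here explains this loss.

On these data alone, whether the higher number goes with any ring or with phenyl alone stays open. A cyclohexyl or benzyl group in this place could separate those two readings, and a phenyl carrying a chlorine or a methoxy group could show whether the ring tolerates substituents.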